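Replacing the methylcarbamoyl of compound 3 with pyrrolidin-1-yl

This account rests on a few compounds, and the source may have more. Where it says the series, first, only, none or still open, it means among the compounds named here.

Of the compounds shown here, three sharing one core have been measured in an assay on cells for inhibition of MAP kinase-interacting serine/threonine-protein kinase 2 (Homo sapiens), read by mobility shift assay, with stated times of 10 min and 60 min, in the presence of a further agent that is not named here; a lower number here means a stronger inhibitor, a higher number a weaker inhibitor. Compound 1 `Cc1[nH]ncc1-c1cncc(-c2ccc(C(N)=O)c(OC(C)C)c2)c1` gives 16 nM. Compound 2 `CC(C)Oc1cc(-c2cncc(-c3cnn(C(C)C)c3)c2)ccc1C(N)=O` gives 42 nM. Compound 3 `CNC(=O)c1cncc(-c2ccc(C(N)=O)c(OC(C)C)c2)c1` gives 630 nM, the highest of the three numbers; its nearest neighbour is compound 2, with a step of a 15-fold higher number from compound 2 to compound 3 (1.18 log units; beyond the scatter), and its furthest is compound 1, with a step of a 39-fold higher number from compound 1 to compound 3 (1.60 log units; beyond the scatter). Between the two pyrazole-bearing compounds the step is only a 2.6-fold higher number from compound 1 to compound 2 (0.42 log units; beyond the scatter).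

Compound 4 `CC(C)Oc1cc(-c2cncc(N3CCCC3)c2)ccc1C(N)=O` is not yet measured. Its change from compound 3 is pyrrolidin-1-yl in place of methylcarbamoyl on an aromatic carbon. The two steps that bear on this position, from compound 1 to compound 3 and from compound 2 to compound 3, both show that exchanging the methylcarbamoyl for a ring at this carbon moves the number a long way downward. Pyrrolidin-1-yl is, however, a non-aromatic ring without a hydrogen-bond donor, unlike either pyrazole, so only part of that movement is expected to carry over. The step from compound 3 to compound 4 is expected to be a 3.2-fold lower number from compound 3 to compound 4 (0.50 log units; beyond the scatter), a lower number, beyond the scatter. Compound 4 is therefore estimated at 200 nM, within a range from 60 nM to 700 nM.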

Compound 4, half-maximal inhibitory concentration: 500 nM
For compound 4 the middle estimate is 2.5-fold (0.40 log units) below the measured one; the range from low to high includes it.
By their numbers in this assay, from the lowest: compound 1; then compound 2; then compounds 4 and 3 (each within the scatter of the next).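

In this assay, putting pyrrolidin-1-yl in place of methylcarbamoyl on this aromatic carbon gives a 1.3-fold lower number from compound 3 to compound 4 (0.10 log units; within the scatter), so two groups that differ in a ring, a double bond outside aromatic rings and a hydrogen-bond donor cannot be told apart here. The large gaps to the pyrazole-bearing compounds remain, at a 12-fold higher number from compound 2 to compound 4 (1.08 log units; beyond the scatter) and a 31-fold higher number from compound 1 to compound 4 (1.49 log units; beyond the scatter), which shows that among these compounds a five-membered ring at this carbon does not by itself bring the number down; only 1-isopropyl-1H-pyrazol-4-yl and 5-methyl-1H-pyrazol-4-yl give the lower numbers. No measurement shown here accounts for the gap between pyrrolidin-1-yl and the two pyrazolyl groups.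

The compounds shown leave open whether an unsubstituted 1H-pyrazol-4-yl or a pyridin-3-yl at this carbon would stand with compound 1 and compound 2, or with compound 3 and compound 4. They also leave open whether a morpholin-4-yl, a piperidin-1-yl or an open-chain amine such as dimethylamino would stay within the scatter of compound 4 in this assay.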